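Aminopyrimidine anilines: pyrazole for methoxyphenyl, compound 3

This account rests on a few compounds, and the source may have more. Where it says the series, first, only, none or still open, it means among the compounds named here.

Two compounds from the series have been run in an assay on cells for inhibition of S-adenosylmethionine decarboxylase proenzyme (Homo sapiens), read by mass spectrometry, at pH 7.2 (a lower number here means a stronger inhibitor, a higher number a weaker inhibitor), and neither gave a number. Compound 1 `Cc1cc(Nc2cc(C(=O)O)cc(C(=O)O)c2)nc(N)n1` returned only the limit > 180000 nM in this assay. Compound 2 `COc1ccc(-c2cc(Cl)cc(Nc3cc(C)nc(N)n3)c2)cc1` likewise returned only the limit > 180000 nM in this assay. Within the data shown here, compound 2 thus stands at the limit, where the one other value shown also sits (the limit of > 180000 nM in this assay, at which 2 of the 2 values shown sit); there is no measured step between compounds, and nothing in the two values separates them.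

Compound 3 `Cc1cc(Nc2cc(Cl)cc(-c3cnn(C)c3)c2)nc(N)n1` differs from compound 2 by 1-methyl-1H-pyrazol-4-yl in place of 4-methoxyphenyl on an aromatic carbon. Among the measured compounds shown here, no measured step shows what size of change this brings, since both values so far are limits. The expectation is no step beyond the scatter, with compound 3 remaining at or near the limit, so the step from compound 2 to compound 3 is estimated as a step that the limit leaves unreadable from compound 2 to compound 3. Compound 3 is expected to give about 250000 nM in this assay, within a range from 60000 nM to 1000000 nM, and most likely a limit again rather than a number.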

Compound 3, half-maximal inhibitory concentration: > 180000 nM
Compound 3 ended at the assay's limit; the forecaster's own chance of this, stated with the estimate: 85%; the middle value does not contradict the limit.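

Compound 2 and compound 3 both end at the limit, not at a number, so no step can be read between them: the limit of > 180000 nM in this assay, at which 3 of the 3 values shown sit.

The compounds shown leave open whether any member of the series gives a measurable value in this assay, and so what 1-methyl-1H-pyrazol-4-yl in place of 4-methoxyphenyl changes.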